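From cyclopropyl to dimethylamino on the sulfonyl sulfur

The source may hold more compounds than are shown below. What is called first, only, known or untested is meant among the compounds shown, and "the series" means these compounds.

In a physicochemical assay for solubility, using the shake flask method, at pH 1.2 (a lower number here means a less soluble compound, a higher number a more soluble compound), compound 2 (`CC(C)(C)OC(=O)N[C@H]1CCCCC/C=C\[C@@H]2C[C@@]2(C(=O)NS(=O)(=O)C2CC2)NC(=O)[C@@H]2C[C@@H](OC(=O)N3Cc4ccccc4C3)CN2C1=O`) gives 0.5 ug/mL, level with compound 1 (`CC(C)(C)OC(=O)N[C@H]1CCCCC/C=C\[C@@H]2C[C@@]2(C(=O)NS(=O)(=O)C2CC2)NC(=O)[C@@H]2C[C@@H](OC(=O)N3CCc4ccccc4C3)CN2C1=O`) at 0.5 ug/mL. Among the compounds with values here, these two values are the only measurements so far, and they sit close to each other.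

The next compound, compound 3 (`CN(C)S(=O)(=O)NC(=O)[C@@]12C[C@H]1/C=C\CCCCC[C@H](NC(=O)OC(C)(C)C)C(=O)N1C[C@H](OC(=O)N3Cc4ccccc4C3)C[C@H]1C(=O)N2`), keeps everything in compound 2 except one group: dimethylamino in place of cyclopropyl on a sulfonyl sulfur.

Within the data shown here, only one measured step is available, no change at the digits printed from compound 1 to compound 2 (within the scatter). That step concerns a group on a carbonyl carbon, so it bears on this change only indirectly. Among the measured compounds shown here, no measured step exists for any change on the sulfonyl sulfur, and the direction of any shift cannot be read from the data.

For the measured compounds named here, with no change at the digits printed from compound 1 to compound 2 (within the scatter) as the sole guide, no step beyond the scatter is assumed, and the range is kept wide on both sides. The step expected in this assay is no change at the digits printed from compound 2 to compound 3 (within the scatter).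

For compound 3 the estimated value is 0.5 ug/mL, with an expected range of 0.2 ug/mL to 1.5 ug/mL.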

Compound 3, solubility: 0.5 ug/mL
Compound 3: the middle estimate sits on the measured number at the digits printed; the measured number falls inside the stated range.
By their numbers in this assay, from the lowest: compounds 1, 2 and 3 (each within the scatter of the next).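

The sulfonyl sulfur is now a second place in the series with a measured step: in this assay, dimethylamino in place of cyclopropyl gives no change at the digits printed from compound 2 to compound 3 (within the scatter) and so an open group can stand on this sulfur in place of a three-membered ring of carbon only, at the same heavy-atom count, with no step beyond the scatter. The earlier step on the carbonyl carbon, no change at the digits printed from compound 1 to compound 2 (within the scatter), covered only a change of ring size, so the series now holds two single-place changes of different kinds, and neither shows a step beyond the scatter in this assay. No supporting data are available to explain this result at the sulfonyl sulfur.

Whether any group on the sulfonyl sulfur can move the read-out in this assay remains open, since cyclopropyl and dimethylamino are the only two shown there and each has just three heavy atoms. A longer chain such as diethylamino, or a chain carrying a carboxylic acid or a primary amine, would test this place well outside the size range covered so far.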